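Chloro to Hydroxy on a Shared Core: Cytotoxicity Outlook

The source may report more compounds than this note shows. Statements on the series, on what has been measured and on what is new or still open speak of the compounds shown alone.

Compound 1 `CCOC(=O)c1c(-c2cccc(Oc3ccccc3)c2)[nH]c2cc(OC)ccc2c1=O` gives in an ADME assay on BJ cells (Homo sapiens) for cytotoxicity, read by luminescence, with a stated time of 72 h (a higher number here means that more compound is needed for the effect, a lower number that less compound is needed), only a limit, > 21500 nM.
Compound 2 `CCOC(=O)c1c(-c2cccc(Cl)c2)[nH]c2cc(OC)ccc2c1=O` gives in this assay only a limit, > 21500 nM.

Compound 2 therefore sits at the limit of > 21500 nM in this assay, at which 2 of the 2 values shown sit, with no number of its own. Among the measured compounds shown here, the one measured step, a step that the two limits leave unreadable from compound 1 to compound 2, is unreadable for the same reason. Compound 3 `CCOC(=O)c1c(-c2cccc(O)c2)[nH]c2cc(OC)ccc2c1=O` differs from compound 2 by hydroxy in place of chloro on an aromatic carbon. No readable step bears on this change, so no size or direction in this assay can be drawn from the data; compound 3 is expected to remain at the limit as well. Compound 3 is estimated at 30000 nM, between 10000 nM and 100000 nM. The expected step is a step that the limit leaves unreadable from compound 2 to compound 3.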

Compound 3, half-maximal effective concentration: > 21500 nM
Compound 3: only a limit was reported (the forecaster's own chance of this, stated with the estimate: 80%); the middle value lies beyond the limit too.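

Compound 3 gives only a limit, like compound 1 and compound 2, so no step among these three compounds can be read. Going by these compounds, whether phenoxy, chloro and hydroxy differ at all in this assay stays open.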